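Fluoro for nitro on the shared core: cytotoxicity outlook

A few compounds are considered here, and "the series" means these few. Any claim that something is new, unique, unknown or untested is made for them only; others in the source may bear on it.

Compound 1 `CCOC(=O)c1[nH]c(=O)c(C#N)cc1C(=O)c1ccc(Cl)cc1` and compound 2 `CCOC(=O)c1[nH]c(=O)c(C#N)cc1C(=O)c1ccc([N+](=O)[O-])cc1` share one core. In an ADME assay on J774.A1 cells (Mus musculus) for cytotoxicity, read by MTT assay, with a stated time of 48 h (a lower number here means that less compound is tolerated, a higher number that more compound is tolerated), compound 1 gives < 100000 nM, a limit of the assay. In this assay compound 2 gives < 100000 nM, likewise a limit, so compound 2 stands only at a limit. The step that the two limits leave unreadable from compound 1 to compound 2 stays unreadable because of the limit of < 100000 nM in this assay, at which 2 of the 2 values shown sit. Compound 3 `CCOC(=O)c1[nH]c(=O)c(C#N)cc1C(=O)c1ccc(F)cc1` differs from compound 2 by fluoro in place of nitro on an aromatic carbon. No readable measured step bears on this change, so no step beyond the scatter is expected in this assay. Compound 3 is estimated at 40000 nM, range 8000 nM to 100000 nM. The expected step is a step that the limit leaves unreadable from compound 2 to compound 3, within the scatter.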

Compound 3, half-maximal cytotoxic concentration: < 100000 nM
Compound 3 was reported as a limit; the forecaster's own chance of this, stated with the estimate: 75%; the middle value lies beyond the limit too.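

No step among compound 1, compound 2 and compound 3 can be read in this assay, because all three stand at a limit: the limit of < 100000 nM in this assay, at which 3 of the 3 values shown sit.

As far as these compounds go, whether chloro, nitro or fluoro on the shared core makes any difference to the tolerated concentration stays open.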